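The compounds below may be only part of what the source reports. "The series", "measured", "known", "first", "only" and "open" are said of these compounds alone.

Two hydrazone ureas on a shared acetamido sugar core have been measured so far. Compound 1 `CC(=O)N[C@H]1/C(=N/NC(=O)Nc2cccc3ccccc23)O[C@H](CO)[C@@H](O)[C@@H]1O` carries a naphthyl urea, and in an assay on isolated protein (Homo sapiens) for inhibition of HEXA/HEXB (Bos taurus), using a Dixon plot (a higher number here means a weaker inhibitor, a lower number a stronger inhibitor), compound 1 gives 154 nM. Compound 2 `CC(=O)N[C@H]1/C(=N/NC(=O)Nc2ccc(C)cc2)O[C@H](CO)[C@@H](O)[C@@H]1O` carries a methylphenyl urea, and in this assay compound 2 gives 332 nM. Of the two numbers, compound 2 stands at the higher one, and the gap to compound 1 lies beyond the usual scatter, so compound 2 is the weaker inhibitor of the pair.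

Compound 3 `CC(=O)N[C@H]1/C(=N/NC(=O)Nc2ccc(C(F)(F)F)cc2)O[C@H](CO)[C@@H](O)[C@@H]1O` is not yet measured. It differs from compound 2 in one place: trifluoromethyl in place of methyl on an aromatic carbon. Going by the values given here, no pair among the measured compounds shows what such a change does here, so the step from compound 2 to compound 3 can only be guessed. A modest step in either direction, or none beyond the scatter, is expected for compound 3 in this assay. The estimated step of a 1.1-fold lower number from compound 2 to compound 3 (0.04 log units; within the scatter) is small. Compound 3 is therefore expected to give about 300 nM, within a range from 120 nM to 800 nM.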

Compound 3, inhibition constant: 125 nM
For compound 3 the middle estimate is 2.4-fold (0.38 log units) above the measured one; low and high end bracket the measured number.
By their numbers in this assay, from the lowest: compounds 3 and 1 (each within the scatter of the next); then compound 2.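

Going by these compounds alone, the pair gives the first reading of a single change: in this assay, trifluoromethyl in place of methyl on an aromatic carbon, para to a large group, brings a 2.7-fold lower number from compound 2 to compound 3 (0.42 log units; beyond the scatter) and so moves the number by a modest amount that exceeds the usual scatter. This place on the six-membered aromatic ring is therefore not indifferent to what it carries, and here four heavy atoms in place of one go with a stronger inhibitor rather than a weaker one. Nothing at hand bears on what lies behind this step, so it stands as an observation about one pair of compounds.

From the compounds shown here alone, what remains open is whether this single step marks a trend at this place, since a chlorine atom, a methoxy group, a nitrile, a carboxylic acid or an amine there would each test it, as would the bare ring with only hydrogen. Going by these compounds, it is also open whether trifluoromethyl would bring a similar step at another place on the ring or on the naphthyl urea of compound 1.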